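The source may report more compounds than this note shows. Statements on the series, on what has been measured and on what is new or still open speak of the compounds shown alone.

Compound 1, `Fc1ccc(-c2cn(C3CN4CCC3CC4)nn2)cc1`, was tested in an assay on HEK293 cells for displacement of a labelled ligand from Neuronal acetylcholine receptor; alpha3/beta4 (Homo sapiens), read by scintillation counting, with a stated time of 120 min (a higher number here means a weaker inhibitor, a lower number a stronger inhibitor), and gave 8.5 nM. Among the three measured compounds it stands second highest; its nearest neighbour is compound 2, `Fc1ccc(COc2cccc(-c3cn(C4CN5CCC4CC5)nn3)c2)cc1`, which in this assay gives 13.9 nM, a gap that lies within the scatter, while the furthest is compound 3, `Fc1ccc(-c2cn([C@@H]3CN4CCC3CC4)nn2)cc1`, which in this assay gives 3.09 nM. Within the data shown here, the one measured step, a 2.8-fold lower number from compound 1 to compound 3 (0.44 log units; beyond the scatter), is modest and concerns only the drawn configuration at a ring carbon of the shared core; it is noted because of the fact that one of compounds 1 and 3 is drawn with a defined configuration and the other without, at the place where they differ.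

Compound 4, `Oc1ccc(-c2cn(C3CN4CCC3CC4)nn2)cc1`, differs from compound 1 by hydroxy in place of fluoro on an aromatic carbon. Among the measured compounds shown here, no measured step touches this position on the six-membered aromatic ring, so the measured steps give no direct guide, and neither compound 2 nor compound 3 varies here. The expected outcome is therefore a step of a 1.2-fold higher number from compound 1 to compound 4 (0.07 log units; within the scatter), that is none beyond the scatter. Compound 4 is estimated at 10 nM in this assay, within a range of 3 nM to 35 nM.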

Compound 4, inhibition constant: 3.44 nM
The estimate for compound 4 lay 2.9-fold (0.46 log units) above the measured number; the range from low to high includes it.
By their numbers in this assay, from the lowest: compounds 3 and 4 (each within the scatter of the next); then compounds 1 and 2 (each within the scatter of the next).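

The change of fluoro to hydroxy gives a 2.5-fold lower number from compound 1 to compound 4 (0.39 log units; beyond the scatter) in this assay, so this carbon of the six-membered aromatic ring, para to a large group, does not behave as a silent position. Among these compounds, the earlier compounds could not show this, as their one measured step concerned only a drawn configuration at a ring carbon of the shared core; this is the first measured step to rest on a change of substituent, and it is modest in size. Going by these compounds, whether an amine, a carboxylic acid or a methoxy group on this carbon would move the number the same way remains open, as does whether the step from fluoro to hydroxy would hold with the configuration drawn in compound 3. Nothing available here bears on why this exchange lowers the number.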